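Lengthening a Chain Across Two Cores

The source may hold more compounds than are shown below. What is called first, only, known or untested is meant among the compounds shown, and "the series" means these compounds.

Measured so far:
Compound 1, `CCCC(=O)O[C@]12C=CC(=O)C[C@H]1OCC2`, in a functional assay on P388 cells (Mus musculus) for cytotoxicity (a lower number here means a stronger inhibitor, a higher number a weaker inhibitor), compound 1 gives 0.6 ug/mL.
Compound 2, `CCCCCC(=O)O[C@]12C=CC(=O)C[C@H]1OCC2`, in this assay compound 2 gives 0.3 ug/mL.
Compound 3, `CCCC(=O)O[C@]12C=CC(O)C[C@H]1OCC2`, in this assay compound 3 gives > 100 ug/mL, which is a limit of the assay and not a number.

Compound 1 and compound 2 share one core and differ only by ethyl in place of hydrogen on a saturated chain carbon, three bonds along the chain from a carbonyl carbon. That change gave a 2.0-fold lower number from compound 1 to compound 2 (0.30 log units; within the scatter), so the two values cannot be told apart with confidence.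

Compound 4, `CCCCCC(=O)O[C@]12C=CC(O)C[C@H]1OCC2`, has not yet been measured. It stands to compound 3 exactly as compound 2 stands to compound 1: it carries ethyl in place of hydrogen on a saturated chain carbon, three bonds along the chain from a carbonyl carbon, the same change as before, made at the same place. How the core of compound 3 differs from the core of compound 1 is not broken down here.

Compound 3 sits at the limit of > 100 ug/mL in this assay, at which 1 of the 3 values shown sits, where one of the three values shown rests. Among the measured compounds shown here, the only measured instance of this change, from compound 1 to compound 2, stayed within the usual scatter, so the expectation is that compound 4 will likewise stay close to compound 3, with an expected step that the limit leaves unreadable from compound 3 to compound 4. Compound 4 is therefore expected to give 150 ug/mL in this assay, most likely reported again only as a limit, with a plausible range from 40 ug/mL to 600 ug/mL.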

Compound 4, half-maximal inhibitory concentration: 38.5 ug/mL
Beside the measured number, compound 4's estimate is 3.9-fold (0.59 log units) above it; measured number below the stated range.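

Putting ethyl in place of hydrogen, at the same place on the chain, gave an at least 2.5-fold lower number from compound 3 to compound 4 (0.41 log units; beyond the scatter) in this assay, so on the core of compound 3 this small change produced a step larger than ordinary measurement noise. On these data alone, compound 3 gives > 100 ug/mL, which is a limit of the assay and not a number, so the step can be read only as a minimum and its true size remains unknown. This does not show that the change acts more strongly on one core than on the other, nor that it acts alike on both: the same change on two cores in this assay, a 2.0-fold lower number (0.30 log units; within the scatter) from compound 1 to compound 2 and an at least 2.5-fold lower number (0.41 log units; beyond the scatter) from compound 3 to compound 4; the limit leaves it open whether they differ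

Among the compounds shown here, each core offers only one such pair, and one of those pairs rests on a limit, so no general rule for moving this change between cores can be drawn from these compounds. As far as these compounds go, it also remains open how either core would respond to a chain longer than the pentyl chain, or to a chain ending in an amine or a carboxylic acid, and whether any such group would give a readable value on the core of compound 3.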